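A lactam ring in place of the hydroxyethyl chain

The compounds below may be only part of what the source reports. "The series", "measured", "known", "first", "only" and "open" are said of these compounds alone.

In a functional assay on KG-1 cells (Homo sapiens) for antiproliferative activity (on this read-out lower numbers stand for an effect already at smaller amounts and higher numbers for an effect only at larger amounts of compound), compound 1 `NC(=O)c1cc(Cl)c2c(Cl)c(C#CCO)n([C@H]3CCCNC3)c2n1` gives 301 nM, and compound 2 `NC(=O)c1cc(Cl)c2c(Cl)c(C#CCCO)n([C@H]3CCCNC3)c2n1` gives 56 nM, the lowest of the two single numbers in this assay; compound 3 `NC(=O)c1cc(Cl)c2c(Cl)c(C#CC3CCCO3)n([C@H]3CCCNC3)c2n1` has two entries, 223 nM; 91 nM (2 entries), and no single number. Going by the values given here, the one measured step, a 5.4-fold lower number from compound 1 to compound 2 (0.73 log units; beyond the scatter), concerns the same substituent on a triple-bonded carbon. Compound 4 `CN1CC(C#Cc2c(Cl)c3c(Cl)cc(C(N)=O)nc3n2[C@H]2CCCNC2)CC1=O` differs from compound 2 by 1-methyl-5-oxopyrrolidin-3-yl in place of 2-hydroxyethyl on a triple-bonded carbon. Compound 3, which also carries a ring on a triple-bonded carbon, shows (the several entries of compound 3 in this assay, 223 nM; 91 nM (2 entries)). A ring in place of the open chain is therefore expected to give a modest rise, a 2.7-fold higher number from compound 2 to compound 4 (0.43 log units; beyond the scatter). Compound 4 is estimated at 150 nM, between 50 nM and 500 nM.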

Compound 4, half-maximal effective concentration: 155 nM
Beside the measured number, compound 4's estimate is 1.0-fold (0.01 log units) below it; measured number inside the range.
By their numbers in this assay, from the lowest: compound 2; then compounds 4 and 1 (each within the scatter of the next).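

On a triple-bonded carbon, the 1-methyl-5-oxopyrrolidin-3-yl ring keeps activity in this assay despite having no hydrogen-bond donor, although it does not match the 2-hydroxyethyl chain (a 2.8-fold higher number from compound 2 to compound 4 (0.44 log units; beyond the scatter)). Against the hydroxymethyl chain, the ring shows no separation (a 1.9-fold lower number from compound 1 to compound 4 (0.29 log units; within the scatter)). The only other ring here, in compound 3, gives no single number for comparison: (the several entries of compound 3 in this assay, 223 nM; 91 nM (2 entries)).

The compounds shown leave open whether the hydroxy group or the chain length sets the number of compound 2. They also do not show how a longer chain, an amine or a carboxylic acid would read at this place.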